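The source may report more compounds than this note shows. Statements on the series, on what has been measured and on what is new or still open speak of the compounds shown alone.

Working notes on the series, read in a functional assay on A549 cells (Homo sapiens) for inhibition, read by MTT assay, with a stated time of 72 h; a higher number here means a weaker inhibitor, a lower number a stronger inhibitor. Compound 1 `COc1ccc(-c2nnc(SCCCN3CCN(c4nc5ccccc5o4)CC3)o2)cc1` gives 93500 nM and compound 2 `O=[N+]([O-])c1ccc(-c2nnc(SCCCN3CCN(c4nc5ccccc5o4)CC3)o2)cc1` gives 90800 nM. These two sit level, as the step shows: a 1.0-fold lower number from compound 1 to compound 2 (0.01 log units; within the scatter). Compound 3 `CC(C)(C)Oc1ccc(-c2nnc(SCCCN3CCN(c4nc5ccccc5o4)CC3)o2)cc1` gives 263000 nM, which leaves it apart from both, with a 2.8-fold higher number from compound 1 to compound 3 (0.45 log units; beyond the scatter) and a 2.9-fold higher number from compound 2 to compound 3 (0.46 log units; beyond the scatter). Compound 2 therefore holds the lowest number shown, though not by a margin beyond the scatter over compound 1.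

The open question is compound 4 `O=C(NCc1nnc(SCCCN2CCN(c3nc4ccccc4o3)CC2)o1)c1ccccc1`, reached from compound 2 by benzamidomethyl in place of 4-nitrophenyl on an aromatic carbon. This exchange is wider than anything measured so far. The three measured steps only swap groups on the six-membered aromatic ring of carbon, whereas here that whole 4-nitrophenyl group goes and benzamidomethyl enters. They bear on it only loosely. Their largest size, seen in a 2.9-fold higher number from compound 2 to compound 3 (0.46 log units; beyond the scatter), is modest, so a step of about that size is expected at most, and the data fix no firm direction. A small move is expected in this assay, leaning weakly upward, as estimated in a 1.2-fold higher number from compound 2 to compound 4 (0.08 log units; within the scatter). For compound 4 the estimated value is 110000 nM, with an expected range of 40000 nM to 300000 nM.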

Compound 4, half-maximal inhibitory concentration: 102000 nM
Beside the measured number, compound 4's estimate is 1.1-fold (0.03 log units) above it, within the range that was stated.
By their numbers in this assay, from the lowest: compounds 2, 1 and 4 (each within the scatter of the next); then compound 3.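

In this assay, among the compounds shown here, the earlier compounds varied only a group carried on the six-membered aromatic ring, whereas compound 4 shows that the whole aryl group on this aromatic carbon of the five-membered ring can be exchanged for benzamidomethyl with no step beyond the scatter against either the 4-nitrophenyl or the 4-methoxyphenyl member (a 1.1-fold higher number from compound 2 to compound 4 (0.05 log units; within the scatter); a 1.1-fold higher number from compound 1 to compound 4 (0.04 log units; within the scatter)). This holds even though benzamidomethyl brings a hydrogen-bond donor where 4-nitrophenyl has none, and it keeps the separation from the 4-(tert-butoxy)phenyl member (a 2.6-fold lower number from compound 3 to compound 4 (0.41 log units; beyond the scatter)), so among these four compounds only compound 3 stands apart. No measurement shown here bears on why the numbers fall this way.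

As far as these compounds go, whether an amine or a carboxylic acid on this aromatic carbon, or a longer chain in place of benzamidomethyl, would move the number beyond the scatter of compound 2 stays open. Also open, from the compounds shown here alone, is whether the same level reading would hold for changes elsewhere on the shared core.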